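Swapping a methylsulfonylphenyl for a chlorothiazole at the piperazine

The compounds below may be only part of what the source reports. "The series", "measured", "known", "first", "only" and "open" are said of these compounds alone.

Measured compounds:
- compound 1, `CCN(Cc1ccccc1)C(=O)C1CCN(CCCN(C(=O)C2CCN(C(C)=O)CC2)c2ccc(C)c(Cl)c2)CC1`: 83.9 nM
- compound 2, `CC(=O)N1CCC(C(=O)N(CCCN2CCN(Cc3ccc(S(C)(=O)=O)cc3)CC2)c2ccc(C)c(Cl)c2)CC1`: > 49200 nM

Of the compounds shown here, two have been measured in an ADME assay (Homo sapiens) for cytotoxicity; on this read-out lower numbers stand for higher toxicity in this test and higher numbers for lower toxicity in this test. Compound 1, `CCN(Cc1ccccc1)C(=O)C1CCN(CCCN(C(=O)C2CCN(C(C)=O)CC2)c2ccc(C)c(Cl)c2)CC1`, gives 83.9 nM in this assay. For compound 2, `CC(=O)N1CCC(C(=O)N(CCCN2CCN(Cc3ccc(S(C)(=O)=O)cc3)CC2)c2ccc(C)c(Cl)c2)CC1`, this assay returned only a limit, > 49200 nM, which is the limit of > 49200 nM in this assay, at which 1 of the 2 values shown sits. Among the measured compounds shown here, compound 2 therefore stands at the low-toxicity end of what has been seen, while compound 1 sits far from that limit; no single-point step connects the two, so their values are only read side by side.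

Compound 3, `CC(=O)N1CCC(C(=O)N(CCCN2CCN(Cc3cnc(Cl)s3)CC2)c2ccc(C)c(Cl)c2)CC1`, is not yet measured. It differs from compound 2 in one place: 2-chloro-1,3-thiazol-5-yl in place of 4-(methylsulfonyl)phenyl on a saturated chain carbon bound to an amine nitrogen in a ring. Because compound 2 sits at the limit (the limit of > 49200 nM in this assay, at which 1 of the 2 values shown sits), any move that is not itself a limit must appear as a step toward lower numbers, that is toward higher toxicity in this assay. The expected step is moderate and is written as an at least 1.9-fold lower number from compound 2 to compound 3 (0.29 log units; that floor lies within the scatter). Compound 3 is estimated to give 25000 nM, with a likely range from 8000 nM to 60000 nM, and a fair chance that this assay again reports only a limit.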

Compound 3, half-maximal cytotoxic concentration: > 52300 nM
Compound 3: only a limit was reported (the forecaster's own chance of this, stated with the estimate: 40%); at least 2.0-fold (0.32 log units) between middle value and limit.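

In this assay compound 3 gives > 52300 nM as a limit of the assay, not a number. Compound 2 also stands only at a limit, so the step between compound 2 and compound 3 cannot be read. As far as these compounds go, whether 2-chloro-1,3-thiazol-5-yl in place of 4-(methylsulfonyl)phenyl changes the read-out at all, and in which direction, stays open.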